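From ethoxycarbonyl to 1-methyl-1H-pyrazol-4-yl on a shared core

The source may hold more compounds than are shown below. What is called first, only, known or untested is meant among the compounds shown, and "the series" means these compounds.

In a functional assay on HeLa cells (Homo sapiens) for inhibition, read by CCK-8 assay, with a stated time of 48 h (on this read-out lower numbers stand for stronger inhibition and higher numbers for weaker inhibition), compound 1 (`COc1cc(-c2ccnc3cc(-c4ccccc4)nn23)cc(OC)c1OC`) gives 458 nM. Compound 2 (`CCOC(=O)c1ccc(-c2cc3nccc(-c4cc(OC)c(OC)c(OC)c4)n3n2)cc1`) carries an ethoxycarbonyl in place of hydrogen on an aromatic carbon. Compound 2 gives > 10000 nM, which is a limit of the assay and not a number. Compound 3 (`COc1cc(-c2ccnc3cc(-c4ccc(-c5cnn(C)c5)cc4)nn23)cc(OC)c1OC`) has 1-methyl-1H-pyrazol-4-yl in place of ethoxycarbonyl, on an aromatic carbon of a six-membered aromatic ring of carbon only: 1-methyl-1H-pyrazol-4-yl in place of ethoxycarbonyl on an aromatic carbon. Among the compounds with values here, one measured step bears on this change: an at least 21-fold higher number from compound 1 to compound 2 (1.33 log units; beyond the scatter), a large step beyond the scatter. Within the data shown here, that step shows only that ethoxycarbonyl is poorly tolerated, and no measured compound carries the incoming group, so some of the lost inhibition may return, though probably not all. The expected change in this assay is an at least 4.0-fold lower number from compound 2 to compound 3 (0.60 log units; beyond the scatter), an estimated move towards stronger inhibition. For compound 3 the estimate is 2500 nM, with an expected range of 500 nM to 10000 nM.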

Compound 3, half-maximal inhibitory concentration: 1830 nM
Compound 3: the middle estimate sits 1.4-fold (0.14 log units) above what was measured; the range from low to high includes it.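

This position, on an aromatic carbon of a six-membered aromatic ring of carbon only, can carry a group and still give a measurable value in this assay: the change to 1-methyl-1H-pyrazol-4-yl gives an at least 5.4-fold lower number from compound 2 to compound 3 (0.73 log units; beyond the scatter). Going by these compounds, compound 2 stands at a limit of the assay and not a number, so the true size of that step stays unknown: the limit of > 10000 nM in this assay, at which 1 of the 3 values shown sits. Hydrogen still does better than the new group, with a 4.0-fold higher number from compound 1 to compound 3 (0.60 log units; beyond the scatter), so the position accepts a group here only at some cost.

Both groups count the same hydrogen-bond acceptors, and the compounds shown cannot tell whether the aromatic ring of the entering group accounts for the difference between them. On these data alone, whether a single fluorine atom or an amine at this position would come closer to compound 1 remains open.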